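Chloro to Fluoro: One Atom Changed at the Far End

The compounds below may be only part of what the source reports. "The series", "measured", "known", "first", "only" and "open" are said of these compounds alone.

Of the compounds shown here, three sharing an amidine-bearing core have been tested in a functional assay on CAKI-1 cells (Homo sapiens) for inhibition, read by sulforhodamine B assay, with a stated time of 48 h; on this read-out lower numbers stand for stronger inhibition of growth and higher numbers for weaker inhibition of growth. Compound 1 `N=C(N)c1ccc(-c2ccc(-c3ccc(Cl)cc3)s2)s1` gives 1610 nM. Compound 2 `N=C(N)c1ccc(-c2ccc(-c3cncc4ccccc34)s2)s1` gives 1600 nM, a number indistinguishable from that of compound 1 within the usual scatter. Compound 3 `N=C(N)c1ccc(-c2ccc(-c3ccccc3)o2)o1` gives 3400 nM, a higher number than compound 1, and this gap lies beyond the scatter. Compound 1 therefore stands second highest of the three numbers. Compound 4 `N=C(N)c1ccc(-c2ccc(-c3ccc(F)cc3)s2)s1`, not yet measured, differs from compound 1 by fluoro in place of chloro on an aromatic carbon. Within the data shown here, no measured pair shows this change, so nothing here sets its size; the step expected in this assay is a 1.4-fold higher number from compound 1 to compound 4 (0.14 log units; within the scatter), which is none beyond the scatter. Compound 4 is estimated at 2200 nM, within 1000 nM to 5000 nM.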

Compound 4, concentration for 50% growth inhibition: 1680 nM
The estimate for compound 4 lay 1.3-fold (0.12 log units) above the measured number; low and high end bracket the measured number.
By their numbers in this assay, from the lowest: compounds 2, 1 and 4 (each within the scatter of the next); then compound 3.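

In this assay, fluoro in place of chloro on an aromatic carbon, para to a large group, gives a 1.0-fold higher number from compound 1 to compound 4 (0.02 log units; within the scatter), a step within the scatter. Among these compounds, this read-out therefore cannot tell these two halogens apart at this position, something no earlier pair could show. Nothing measured here offers an explanation for this result.

As far as these compounds go, whether a different kind of group at this position, such as an amine or a carboxylic acid, would separate from compound 1 stays open. So does whether this swap would behave the same way on another core.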